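A few compounds are considered here, and "the series" means these few. Any claim that something is new, unique, unknown or untested is made for them only; others in the source may bear on it.

Measured so far in a functional assay on DU-145 cells (Homo sapiens) for inhibition, read by trypan blue exclusion, with a stated time of 72 h; on this read-out higher numbers stand for weaker inhibition and lower numbers for stronger inhibition:
- compound 1 `CCCn1c(=O)c(S(=O)(=O)c2ccc(F)cc2F)cc2cnc(Nc3ccc4[nH]ccc4c3)nc21`: 1000 nM
- compound 2 `Cn1c(=O)c(S(=O)(=O)c2ccc(F)cc2F)cc2cnc(Nc3cnc4[nH]ccc4c3)nc21`: 750 nM

For the measured compounds named here, these are the only two numbers in hand, and they lie within the scatter of each other. Compound 1 at 1000 nM therefore cannot be ranked against compound 2 at 750 nM. The two compounds also differ in more than one place, so the pair isolates no single structural change.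

The next comparison is compound 3 `CCn1c(=O)c(S(=O)(=O)c2ccc(F)cc2F)cc2cnc(Nc3ccc4[nH]ccc4c3)nc21` against compound 1. Compound 3 has hydrogen in place of methyl on a saturated chain carbon, two bonds along the chain from an aromatic nitrogen. The same difference reads as propyl to ethyl. The rest of the structure is unchanged.

Going by the values given here, no measured pair shows what this change does in this assay, so there is no direct precedent for its size or direction. The working expectation is no step beyond the scatter, with the estimate anchored on compound 1 at 1000 nM. The estimated step of a 1.3-fold lower number from compound 1 to compound 3 (0.10 log units; within the scatter) is expected to stay within the scatter. For compound 3 the expected value is 800 nM, with an estimated range of 300 nM to 2000 nM.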

Compound 3, half-maximal inhibitory concentration: 750 nM
For compound 3 the middle estimate is 1.1-fold (0.03 log units) above the measured one; the range from low to high includes it.
By their numbers in this assay, from the lowest: compounds 2, 3 and 1 (each within the scatter of the next).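

In this assay, for the compounds shown here, hydrogen in place of methyl on a saturated chain carbon, two bonds along the chain from an aromatic nitrogen, gives a 1.3-fold lower number from compound 1 to compound 3 (0.12 log units; within the scatter) as the first step that isolates a single place. At this position, propyl and ethyl therefore cannot be told apart on this read-out, which is something the earlier pair, differing in more than one place, could not show. No measurement on these compounds accounts for this result or bears on the chain itself.

This single step covers only propyl and ethyl, so a longer chain such as butyl, a branched chain such as isopropyl, or a chain ending in an amine or a carboxylic acid remains an open case at this position. On these data alone, compound 2 carries methyl here but also differs from compound 3 elsewhere, so the step from ethyl to methyl cannot be read, and the contribution of the other differing place remains open as well.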